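Toward compound 4: from methoxyacetamide back to a heteroaryl carbamoyl

The compounds below may be only part of what the source reports. "The series", "measured", "known", "first", "only" and "open" are said of these compounds alone.

Measured in a functional assay on KBVIN cells (Homo sapiens) for antiproliferative activity, read by sulforhodamine B assay, with a stated time of 3 days; a higher number here means a weaker inhibitor of growth, a lower number a stronger inhibitor of growth:
Compound 1 `O=C(Nc1ccccn1)c1cccc(Nc2ncc(F)c(Nc3ccc(F)cc3)n2)c1`: 13700 nM
Compound 2 `O=C(Nc1cccc(Nc2ncc(F)c(Nc3ccc(F)cc3)n2)c1)c1ccccc1`: > 10000 nM (a limit)
Compound 3 `COCC(=O)Nc1cccc(Nc2ncc(F)c(Nc3ccc(F)cc3)n2)c1`: 3940 nM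

Compound 3 gives 3940 nM, the lowest of the two actual numbers in this assay. The gap to the nearest number is a 3.5-fold lower number from compound 1 to compound 3 (0.54 log units; beyond the scatter). Compound 2 gives > 10000 nM, which is a limit and not a number.

In compound 4 `Cn1ccnc1NC(=O)c1cccc(Nc2ncc(F)c(Nc3ccc(F)cc3)n2)c1`, (1-methyl-1H-imidazol-2-yl)carbamoyl stands in place of ((methoxymethyl)carbonyl)amino on an aromatic carbon ((1-methyl-1H-imidazol-2-yl)carbamoyl in place of ((methoxymethyl)carbonyl)amino on an aromatic carbon). This undoes the kind of exchange seen in the closest measured step, a 3.5-fold lower number from compound 1 to compound 3 (0.54 log units; beyond the scatter), where ((methoxymethyl)carbonyl)amino took the place of (pyridin-2-yl)carbamoyl. The other step ending at the same group, an at least 2.5-fold lower number from compound 2 to compound 3 (0.40 log units; beyond the scatter), points the same way, though its size is bounded by a limit. Neither step involves a five-membered ring, so the match is only partial. A modest rise in the number in this assay is therefore expected, of about the size of the step from compound 1, reversed and somewhat smaller. The expected change is a 2.3-fold higher number from compound 3 to compound 4 (0.36 log units; beyond the scatter). For compound 4 the estimated value is 9000 nM, with an expected range from 3500 nM to 22000 nM.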

Compound 4, concentration for 50% growth inhibition: 13100 nM
Estimate against measurement, compound 4: 1.5-fold (0.16 log units) below; measured number inside the range.
By their numbers in this assay, from the lowest: compound 3; then compounds 4 and 1 (each within the scatter of the next).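

In this assay, setting (1-methyl-1H-imidazol-2-yl)carbamoyl in place of ((methoxymethyl)carbonyl)amino on this aromatic carbon gives a 3.3-fold higher number from compound 3 to compound 4 (0.52 log units; beyond the scatter), so the gap between compound 3 and the pyridin-2-yl compound is now matched by a second heteroaryl carbamoyl with a five-membered aromatic ring. Exchanging pyridin-2-yl for 1-methyl-1H-imidazol-2-yl on the amide-type nitrogen gives a 1.0-fold lower number from compound 1 to compound 4 (0.02 log units; within the scatter), so this change of ring, with its 2 hetero atoms, leaves no readable difference in this assay. The step from compound 2 to compound 4 cannot be read, as the value of compound 2 is a limit and not a number: the limit of > 10000 nM in this assay, at which 1 of the 4 values shown sits.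

Compound 3 alone carries both the amide turned the other way round and the methoxymethyl chain, and the compounds shown do not separate these two features. An acetamido group in the same place, or a carbamoyl bearing a 2-methoxyethyl chain on its nitrogen, would be needed to tell whether the lower number of compound 3 goes with the direction of the amide or with the loss of the aromatic ring.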